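Methyl on the Amine of Compound 2

This account rests on a few compounds, and the source may have more. Where it says the series, first, only, none or still open, it means among the compounds named here.

In an in vivo ADME assay on the whole organism for pharmacokinetics, with Canis familiaris (Canis lupus familiaris) as the target (a higher number here means that a larger share of the oral dose reaches the circulation, a lower number that a smaller share of the oral dose reaches the circulation), compound 2 `CNCc1ccccc1-c1ccc(N2CCc3c(C(F)(F)F)nn(-c4ccc5onc(N)c5c4)c3C2=O)cc1` gives 67%, the lower of the two measured values, whereas compound 1 `Nc1noc2ccc(-n3nc(C(F)(F)F)c4c3C(=O)N(c3ccc(-c5ccccc5CN5CCC(O)CC5)cc3)CC4)cc12` gives 102%. The next compound, compound 3 `CN(C)Cc1ccccc1-c1ccc(N2CCc3c(C(F)(F)F)nn(-c4ccc5onc(N)c5c4)c3C2=O)cc1`, keeps the shared core and changes one place: methyl in place of hydrogen on an amine nitrogen, so that methylamino becomes dimethylamino (methyl in place of hydrogen on an amine nitrogen).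

Within the data shown here, only one measured step bears on this change, and it concerns the same amine position. That step, a number 35 percentage points lower from compound 1 to compound 2 (beyond the scatter), is large and beyond the scatter, and it puts methylamino in place of 4-hydroxypiperidin-1-yl. It shows that this assay can respond to a change at this amine, but it is a much larger exchange than the addition of one methyl. It therefore gives only a loose guide to direction and little guide to size. Among the measured compounds shown here, no measured step isolates the methyl itself.

A small rise that stays within the scatter is expected, and the estimated change is a number 8 percentage points higher from compound 2 to compound 3 (within the scatter). In this assay, the estimate for compound 3 is 75%, with an expected range of 50% to 100%.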

Compound 3, oral bioavailability: 50%
For compound 3 the middle estimate is 25 percentage points above the measured one; low and high end bracket the measured number.
By their numbers in this assay, from the lowest: compound 3; then compound 2; then compound 1.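

In this assay, among these compounds, the methyl alone is enough to move the number, which the earlier compounds could not show: the step is a number 17 percentage points lower from compound 2 to compound 3 (beyond the scatter), modest in size, and it shows that this small change at the amine nitrogen matters on its own and that its direction is downward. The wider exchange at this place also grows, with a number 52 percentage points lower from compound 1 to compound 3 (beyond the scatter), a large step, so that among these three compounds the one with 4-hydroxypiperidin-1-yl stands highest, methylamino in the middle and dimethylamino lowest, with none of the three going against that order. Nothing measured here explains why the added methyl lowers the number, so the step stands as an observation without a known cause.

The compounds shown leave open where a primary amine on the same saturated chain carbon would stand, and thus whether the order from dimethylamino to methylamino extends one step further. They also leave open whether plain piperidin-1-yl, without the hydroxyl, would stand nearer compound 1 or nearer compound 3, which would separate the part played by the ring from that of the hydroxyl.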